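A Urea-End Swap Followed from Compound 2

The compounds below may be only part of what the source reports. "The series", "measured", "known", "first", "only" and "open" are said of these compounds alone.

Compound 2 `COc1cc(Cl)cc(-c2nn(-c3cccc(NC(=O)Nc4ccc(Cl)c(Cl)c4)c3)cc2-c2ccncc2)c1` gives 18.6% in a functional assay on T47D cells (Homo sapiens) for inhibition, read by sulforhodamine B assay, with a stated time of 48 h, tested at 10 uM (on this read-out higher numbers stand for a weaker effect at the one concentration tested and lower numbers for a stronger effect), the highest of the two numbers shown. Its nearest neighbour, compound 1 `COc1cc(Cl)cc(-c2nn(-c3cccc(NC(=O)Nc4ccc(Cl)c(C(F)(F)F)c4)c3)cc2-c2ccncc2)c1`, gives 8.1% in this assay. Among the measured compounds shown here, the one measured step, a number 10.5 percentage points higher from compound 1 to compound 2 (beyond the scatter), came with chloro in place of trifluoromethyl on an aromatic carbon. Compound 3 `COc1cc(Cl)cc(-c2nn(-c3cccc(NC(=O)Nc4cccc(C(F)(F)F)c4)c3)cc2-c2ccncc2)c1` differs from compound 2 by 3-(trifluoromethyl)phenyl in place of 3,4-dichlorophenyl on an amide-type nitrogen. For the measured compounds named here, that change runs back toward trifluoromethyl, the direction opposite to a number 10.5 percentage points higher from compound 1 to compound 2 (beyond the scatter), yet it exchanges the whole 3,4-dichlorophenyl rather than one substituent alone, and for that wider exchange no measured step exists. Going by the values given here, a modest downward step in this assay is therefore expected, though with less certainty than the single measured step alone would give. For compound 3 the expected step is a number 4.6 percentage points lower from compound 2 to compound 3 (within the scatter). Compound 3 is estimated at 14%, with a range from 4% to 32%.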

Compound 3, a percentage reported as activity, at one concentration (the size of the read-out at that concentration, not a potency): -0.45%
Compound 3: middle estimate off by 14.5 percentage points, on the high side; the whole stated range lies above it.
By their numbers in this assay, from the lowest: compounds 3 and 1 (each within the scatter of the next); then compound 2.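

In this assay the exchange of the whole ring on the amide-type nitrogen gives a number 19.1 percentage points lower from compound 2 to compound 3 (beyond the scatter) and so sets 3-(trifluoromethyl)phenyl clearly apart from 3,4-dichlorophenyl at this position. Among the compounds shown here, with trifluoromethyl kept, hydrogen in place of chloro gives a number 8.6 percentage points lower from compound 1 to compound 3 (within the scatter) and leaves the two trifluoromethyl compounds within the scatter of each other, while compound 2, the one compound here without trifluoromethyl, lies beyond the scatter of both. Nothing measured here explains this difference. The compounds shown leave open whether trifluoromethyl is itself what matters at this end of the urea, or whether a nitrile or a tert-butyl group there would read the same way. They also leave open whether an unsubstituted phenyl ring would stay within the same scatter.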